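A bromo-bearing core: from ester to primary amine

A few compounds are considered here, and "the series" means these few. Any claim that something is new, unique, unknown or untested is made for them only; others in the source may bear on it.

Compound 1 `N[C@H]1CC[C@H](Nc2c(C(=O)NCc3ccc(F)cc3)nc(N3CCCCC3)c3cccnc23)CC1`: 8000 nM
Compound 2 `COC(=O)CNc1c(C(=O)NCc2ccc(F)cc2)nc(Br)c2cccnc12`: > 10000 nM
Compound 3 `CN(C)c1ccc(CNC(=O)c2nc(Br)c3cccnc3c2N[C@H]2CC[C@H](N)CC2)cc1`: "not determined" (no result reported)

The study measures cytotoxicity in a functional assay on HCT-116 cells (Homo sapiens) for cytotoxicity, read by MTT assay, with a stated time of 72 h; a lower number here means a stronger inhibitor, a higher number a weaker inhibitor. Compound 1 gives 8000 nM in this assay. For compound 2 the assay reports only a limit, > 10000 nM, and not a number; it sits at the limit of the method, as noted in the limit of > 10000 nM in this assay, at which 1 of the 3 values shown sits. For compound 3 the result in this assay is "not determined" (no result reported), so no value is available for it.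

Compound 4 `NCCCNc1c(C(=O)NCc2ccc(F)cc2)nc(Br)c2cccnc12` has not yet been measured. It differs from compound 2 in one place: 2-aminoethyl in place of methoxycarbonyl on a saturated chain carbon bound to a nitrogen on an aromatic ring. The ester-bearing side chain of compound 2 is replaced by the aminopropyl chain, so that compound 4, like compound 1, carries a primary amine on its side chain, while keeping the bromine of compound 2.

Since compound 2 stands only at a limit, the step to compound 4 cannot be anchored to a measured number. Compound 1, which also carries a primary amine, gives 8000 nM, and on that basis a value of the same order is expected for compound 4. The step of an at least 1.1-fold lower number from compound 2 to compound 4 (0.04 log units; that floor lies within the scatter) is expected to be small, toward a stronger inhibitor, and may not exceed the usual scatter. Compound 4 is estimated at 9000 nM, with a range from 3000 nM to 25000 nM.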

Compound 4, half-maximal inhibitory concentration: > 20000 nM
Compound 4 gave a limit, no number (the forecaster's own chance of this, stated with the estimate: 45%); middle value at least 2.2-fold (0.34 log units) away from the limit.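

In this assay compound 4 gives > 20000 nM, which is a limit and not a number. Among the compounds shown here, compound 2 also stands at a limit, > 10000 nM, so no step between compound 2 and compound 4 can be read. The compounds shown leave open whether 3-aminopropyl in place of (methoxycarbonyl)methyl yields a stronger or a weaker inhibitor.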